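The source may hold more compounds than are shown below. What is called first, only, known or untested is meant among the compounds shown, and "the series" means these compounds.

Compound 2 `COc1ccc(C2CC(c3cc(Cl)c(C)cc3O)=NN2c2ccc(S(N)(=O)=O)cc2)cc1OC` gives 23100 nM in a functional assay on NCI-H226 cells (Homo sapiens) for antiproliferative activity, with a stated time of 48 h (a lower number here means a stronger inhibitor of growth, a higher number a weaker inhibitor of growth), which sets it alongside compound 1 `Cc1cc(O)c(C2=NN(c3ccc(S(N)(=O)=O)cc3)C(/C=C/c3ccccc3)C2)cc1Cl`, with 19200 nM, the pair separated only by a 1.2-fold higher number from compound 1 to compound 2 (0.08 log units; within the scatter), a step within the scatter. Compound 3 `COc1ccc(C2CC(c3cc(Cl)c(C)cc3O)=NN2c2ccc(S(N)(=O)=O)cc2)c(OC)c1OC` differs from compound 2 by methoxy in place of hydrogen on an aromatic carbon. For the measured compounds named here, no measured step touches a methoxy added to this ring; the one step available, a 1.2-fold higher number from compound 1 to compound 2 (0.08 log units; within the scatter), exchanges the whole group on the saturated ring carbon and stays within the scatter, so for compound 3 no step beyond the scatter is expected in this assay. Compound 3 is therefore estimated at 23000 nM, range 10000 nM to 52000 nM, a step of a 1.0-fold lower number from compound 2 to compound 3 (0.00 log units; within the scatter).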

Compound 3, concentration for total growth inhibition: 13300 nM
Beside the measured number, compound 3's estimate is 1.7-fold (0.24 log units) above it; the measured number falls inside the stated range.
By their numbers in this assay, from the lowest: compounds 3, 1 and 2 (each within the scatter of the next).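

On the 3,4-dimethoxyphenyl ring, a methoxy ortho to a large group and ortho to a methoxy group, giving 2,3,4-trimethoxyphenyl, keeps the number within the scatter in this assay (a 1.7-fold lower number from compound 2 to compound 3 (0.24 log units; within the scatter)). The 2,3,4-trimethoxyphenyl group also reads within the scatter of the 2-phenylethenyl group (a 1.4-fold lower number from compound 1 to compound 3 (0.16 log units; within the scatter)), so the three groups on the saturated ring carbon remain indistinguishable here. No supporting data bear on these small steps. As far as these compounds go, whether an amine, a carboxylic acid or a longer alkoxy chain at this ring position would give a step beyond the scatter remains open.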